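Amide aryl swap on a flavonol core in HepG2 cells

The source may hold more compounds than are shown below. What is called first, only, known or untested is meant among the compounds shown, and "the series" means these compounds.

Compound 1 `Cc1ccc(C(=O)Nc2cccc(-c3oc4cc(-c5ccc(F)cc5)ccc4c(=O)c3O)c2)cc1`: 2320 nM
Compound 2 `COc1cccc(C(=O)Nc2cccc(-c3oc4cc(-c5ccc(F)cc5)ccc4c(=O)c3O)c2)c1`: 9950 nM

In a functional assay on HepG2 cells (Homo sapiens) for antiproliferative activity, read by CCK-8 assay, with a stated time of 72 h (a higher number here means a weaker inhibitor, a lower number a stronger inhibitor), compound 2 gives the higher of the two numbers, with compound 1 nearest; the step shows a 4.3-fold higher number from compound 1 to compound 2 (0.63 log units; beyond the scatter). Compound 3 `Cc1cc(C(=O)Nc2cccc(-c3oc4cc(-c5ccc(F)cc5)ccc4c(=O)c3O)c2)ccc1F` is not yet measured. It differs from compound 2 in one place: 4-fluoro-3-methylphenyl in place of 3-methoxyphenyl on a carbonyl carbon. For the measured compounds named here, the only measured step that bears on this is a 4.3-fold higher number from compound 1 to compound 2 (0.63 log units; beyond the scatter), which removed a methoxy-free aryl group in favour of the 3-methoxyphenyl; compound 3 again carries no methoxy group, so a step back downwards, of similar size, is expected. The expected step reads a 2.8-fold lower number from compound 2 to compound 3 (0.45 log units; beyond the scatter). Compound 3 is therefore estimated at 3500 nM, within 1200 nM to 10000 nM.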

Compound 3, half-maximal inhibitory concentration: 9540 nM
Compound 3: the middle estimate sits 2.7-fold (0.44 log units) below what was measured, within the range that was stated.
By their numbers in this assay, from the lowest: compound 1; then compounds 3 and 2 (each within the scatter of the next).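

In this assay, 4-fluoro-3-methylphenyl in place of 3-methoxyphenyl on this carbonyl carbon gives a 1.0-fold lower number from compound 2 to compound 3 (0.02 log units; within the scatter), so the two groups cannot be told apart here. Losing the methoxy group is therefore not enough to match compound 1, as a 4.1-fold higher number from compound 1 to compound 3 (0.61 log units; beyond the scatter) shows, and among these three aryl groups only the 4-methylphenyl stands apart. Nothing shown explains this result. Still open, from the compounds shown here alone, is how an aryl ring carrying an amine or a carboxylic acid would read on this carbonyl carbon. Going by these compounds, a longer alkyl chain in place of the ring is equally open.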